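Second bromo on the shared core: from compound 2 to compound 3

This account rests on a few compounds, and the source may have more. Where it says the series, first, only, none or still open, it means among the compounds named here.

Of the compounds shown here, two have been measured in an ADME assay on XF498 cells (Homo sapiens) for cytotoxicity; on this read-out higher numbers stand for an effect only at larger amounts of compound and lower numbers for an effect already at smaller amounts. Compound 1 `O=C1NC[C@@H](c2c[nH]c3cc(Br)ccc23)N=C1c1c[nH]c2ccccc12` gives 8.3 ug/mL in this assay. Compound 2 `O=C(C1=NC(c2c[nH]c3cc(Br)ccc23)CN1)c1c[nH]c2ccccc12` carries the carbonyl in place of the lactam arrangement of compound 1; in this assay compound 2 gives 7.22 ug/mL. Among the compounds with values here, on the numbers so far compound 2 has the lower of the two values, but compound 1 sits a hair away and the two numbers lie within the scatter of each other, so no order between them can be claimed.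

Compound 3 `O=C(C1=NC(c2c[nH]c3cc(Br)ccc23)CN1)c1c[nH]c2cc(Br)ccc12` has not yet been measured in this assay. It differs from compound 2 in one place: bromo in place of hydrogen on an aromatic carbon. Within the data shown here, no step between measured compounds is available for this change, so there is nothing to calibrate its size against. The expectation is a step from compound 2 to compound 3 of a 1.2-fold lower number from compound 2 to compound 3 (0.08 log units; within the scatter) in this assay, that is, a change not clearly beyond the scatter in either direction. For compound 3 the estimated value in this assay is 6 ug/mL, with a range from 2.5 ug/mL to 15 ug/mL.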

Compound 3, concentration for half-maximal effect: 5.16 ug/mL
Compound 3: the middle estimate sits 1.2-fold (0.07 log units) above what was measured; low and high end bracket the measured number.
By their numbers in this assay, from the lowest: compounds 3, 2 and 1 (each within the scatter of the next).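

Within the data shown here, the first single-place step puts bromo in place of hydrogen on an aromatic carbon of a six-membered aromatic ring of carbon only, and in this assay it reads as a 1.4-fold lower number from compound 2 to compound 3 (0.15 log units; within the scatter) at this position. A second bromo on the shared core is therefore accommodated here without a difference that stands clear of the scatter, though one step cannot set a trend for this change. Nothing available accounts for the size of this step.

Still open, going by these compounds, is whether an amine, a carboxylic acid or a methoxy group at this position would also stay within the scatter of compound 2. Also open, on these data alone, is whether the same bromo step would read alike on the lactam arrangement of compound 1 or on other carbons of this ring.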